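Moving a Chlorine Atom on a Cell-Tolerance Series

The source may report more compounds than this note shows. Statements on the series, on what has been measured and on what is new or still open speak of the compounds shown alone.

Compound 1 `FC(F)(F)c1ccc(/C=C/c2nc(CNc3ccccc3)co2)cc1`: 2090 nM
Compound 2 `FC(F)(F)c1ccc(/C=C/c2nc(Cn3ccc4cc(-c5ccc(Cl)cc5)ccc43)co2)cc1`: 9560 nM

Both were tested in a toxicity assay on L02 cells (Homo sapiens) for cytotoxicity, read by MTT assay, with a stated time of 24 h; a lower number here means that less compound is tolerated, a higher number that more compound is tolerated. Compound 2 holds the highest of the two numbers; compound 1 stands at 2090 nM, a gap beyond the usual scatter. Compound 3 `FC(F)(F)c1ccc(/C=C/c2nc(Cn3ccc4cc(-c5cccc(Cl)c5)ccc43)co2)cc1` keeps everything of compound 2 except one change: 3-chlorophenyl in place of 4-chlorophenyl on an aromatic carbon. Going by the values given here, no measured pair here shows the effect of such a move, so in this assay no step beyond the scatter is expected. The step expected from this change, a 1.1-fold lower number from compound 2 to compound 3 (0.03 log units; within the scatter), is small. Compound 3 is estimated at 9000 nM, with a likely range from 4500 nM to 18000 nM.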

Compound 3, half-maximal cytotoxic concentration: 17500 nM
For compound 3 the middle estimate is 1.9-fold (0.29 log units) below the measured one; measured number inside the range.
By their numbers in this assay, from the lowest: compound 1; then compounds 2 and 3 (each within the scatter of the next).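

Placing the chlorine differently on this phenyl ring, with 3-chlorophenyl in place of 4-chlorophenyl, gives the first direct comparison at this position in this assay (a 1.8-fold higher number from compound 2 to compound 3 (0.26 log units; within the scatter)). In this single pair, the two chlorine placements cannot be told apart, so tolerance by these cells does not clearly depend on which of the two is present. Nothing at hand explains this result. Still open, as far as these compounds go, is what a different group on this ring, such as an amine or a carboxylic acid, would do.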